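A few compounds are considered here, and "the series" means these few. Any claim that something is new, unique, unknown or untested is made for them only; others in the source may bear on it.

Measured compounds:
- compound 1 `Clc1ccc(NCc2ccc(CNc3ncccn3)cc2)nc1` — 10 nM
- compound 2 `c1cnc(NCc2ccc(CNc3cccc(N4CCCC4)c3)cc2)nc1` — 10 nM
- compound 3 `c1cnc(NCc2ccc(CNc3ccc(N4CCCC4)cc3)cc2)nc1` — 1 nM

These three compounds share a core and were tested in an assay on MDA-MB-231 cells for displacement of a labelled ligand from C-X-C chemokine receptor type 4 (Homo sapiens); on this read-out higher numbers stand for an effect only at larger amounts of compound and lower numbers for an effect already at smaller amounts. Compound 1 gives 10 nM there, and compound 2 gives 10 nM, so the two stand level at the digits shown, within the usual scatter, and together they hold the highest numbers of the three. Compound 3, with 1 nM, sits lower than compound 1, a gap that lies beyond the scatter. Going by the values given here, for the pair of compound 1 and compound 3, and for compound 2 and compound 3, only the values themselves are known; no step has been worked out.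

Compound 4 `Fc1ccc(NCc2ccc(CNc3ncccn3)cc2)nc1` has not yet been measured. Among the compounds with values here, its single difference from compound 1 is fluoro in place of chloro on an aromatic carbon; read one bond further out, the 5-chloropyridin-2-yl group becomes a 5-fluoropyridin-2-yl group, two atoms from the ring nitrogen and para to a large group. Within the data shown here, no measured pair in this set makes the same change, so there is no step to lean on. The expected step from compound 1 is a modest rise in number, a 2.0-fold higher number from compound 1 to compound 4 (0.30 log units; within the scatter), near the edge of the scatter. Compound 4 is therefore estimated at 20 nM, with a range from 5 nM to 80 nM.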

Compound 4, effective concentration (reported as EC, without a stated level of effect): 1 nM
Compound 4: the middle estimate sits 20-fold (1.30 log units) above what was measured, and the stated range ends above it.
By their numbers in this assay, from the lowest: compounds 3 and 4 (each within the scatter of the next); then compounds 1 and 2 (each within the scatter of the next).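

Replacing the chloro with a fluoro on this aromatic carbon, two atoms from the ring nitrogen and para to a large group, gives a 10-fold lower number from compound 1 to compound 4 (1.00 log units; beyond the scatter) in this assay and lies beyond the scatter, so this position responds clearly to a change of one heavy atom. The earlier compounds shown here could not show this, since none of them formed a pair differing at this place, and the result also shows that the counts of rings, hydrogen-bond donors, acceptors and charge, which are identical for chloro and fluoro, do not predict the size of the step. No supporting measurement is available to explain why the swap has this effect.

The compounds shown leave open how a bromo, a methyl, a methoxy, a nitrile or a plain hydrogen would read at this same carbon, so it remains unknown whether fluoro is unusual here or chloro is the exception. A single pair also cannot tell whether the same swap would give a similar step on a different core.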